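The source may report more compounds than this note shows. Statements on the series, on what has been measured and on what is new or still open speak of the compounds shown alone.

Three compounds have been measured in an assay on CHO cells for displacement of a labelled ligand from adenosine receptor A1 (Homo sapiens), read by scintillation counting, with a stated time of 90 min; a higher number here means a weaker inhibitor, a lower number a stronger inhibitor:

compound 1, `N#Cc1c(N)nc(SCc2cccc(C(N)=O)c2)c(C#N)c1-c1ccc(OCC2CC2)cc1`, giving 83 nM
compound 2, `COC(=O)c1cccc(CSc2nc(N)c(C#N)c(-c3ccc(OCC4CC4)cc3)c2C#N)c1`, giving 66 nM
compound 3, `N#Cc1c(N)nc(SCc2ncc[nH]2)c(C#N)c1-c1ccc(OCC2CC2)cc1`, giving 235 nM

Compound 3 stands at the highest number of the three, so it is the weakest inhibitor among them. The two steps that lead to it are a 2.8-fold higher number from compound 1 to compound 3 (0.45 log units; beyond the scatter) and a 3.6-fold higher number from compound 2 to compound 3 (0.55 log units; beyond the scatter); both are modest and both replace a substituted phenyl group with the 1H-imidazol-2-yl group on the saturated chain carbon bound to a sulfur. Compound 1 and compound 2 differ from each other only in a 1.3-fold lower number from compound 1 to compound 2 (0.10 log units; within the scatter), which stays within the scatter.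

Compound 4, `N#Cc1c(N)nc(SCC2=NCCN2)c(C#N)c1-c1ccc(OCC2CC2)cc1`, differs from compound 3 in a group of 5 heavy atoms (3 carbon, 2 nitrogen; one five-membered non-aromatic ring with 2 hetero atoms) in place of a group of 5 heavy atoms (3 carbon, 2 nitrogen; one five-membered aromatic ring with 2 hetero atoms), on a saturated chain carbon bound to a sulfur. Among the compounds with values here, none of the measured steps swaps an aromatic five-membered ring for a non-aromatic one at this position, so the measured steps bear on it only by showing that changes at this chain carbon have moved the number modestly. A step of similar or smaller size is therefore expected, in either direction, and a 1.3-fold higher number from compound 3 to compound 4 (0.11 log units; within the scatter) is the estimate here. Compound 4 is expected to give about 300 nM, within a range from 100 nM to 900 nM.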

Compound 4, inhibition constant: 483 nM
For compound 4 the middle estimate is 1.6-fold (0.21 log units) below the measured one, and the stated range covers the measured number.
By their numbers in this assay, from the lowest: compounds 2 and 1 (each within the scatter of the next); then compound 3; then compound 4.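

In this assay, the non-aromatic five-membered ring is not a neutral stand-in for the aromatic 1H-imidazol-2-yl on the saturated chain carbon bound to a sulfur, even though both groups have the same count of heavy atoms: the change gives a 2.1-fold higher number from compound 3 to compound 4 (0.31 log units; beyond the scatter). Measured against the groups with a six-membered aromatic ring, the steps are a 7.3-fold higher number from compound 2 to compound 4 (0.86 log units; beyond the scatter) and a 5.8-fold higher number from compound 1 to compound 4 (0.76 log units; beyond the scatter), which makes compound 4 the weakest inhibitor of the four. Nothing available here explains what lies behind these steps.

The compounds shown leave open how a carboxylic acid or a simple amine would fare on this chain carbon. They also leave open whether a longer chain carrying either five-membered ring would change the number.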